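The source may hold more compounds than are shown below. What is called first, only, known or untested is meant among the compounds shown, and "the series" means these compounds.

Compound 1 `COc1ccc(-c2cnc(NC(=O)c3cnc[nH]3)n2C)cc1`: > 100000 nM, a limit.
Compound 2 `Cc1ccc(C(=O)Nc2ncc(-c3ccccc3)n2C)cc1`: > 50000 nM, a limit.

In a toxicity assay on THP-1 cells (Homo sapiens) for inhibition (a lower number here means that less compound is tolerated, a higher number that more compound is tolerated), compound 2 has no exact number, only the limit > 50000 nM. Compound 3 `COc1ccc(-c2cnc(NC(=O)c3ccc(C)cc3)n2C)cc1` has methoxy in place of hydrogen on an aromatic carbon, para to a large group, which reads phenyl to 4-methoxyphenyl: methoxy in place of hydrogen on an aromatic carbon. Compound 1 also carries 4-methoxyphenyl, and its result is likewise a limit, > 100000 nM. Within the data shown here, no measured step isolates this change, so none beyond the scatter is expected in this assay: the expected step is a step that the limit leaves unreadable from compound 2 to compound 3. For compound 3 the estimated value is 60000 nM, with an expected range of 20000 nM to 120000 nM.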

Compound 3, half-maximal cytotoxic concentration: > 100000 nM
Compound 3: a limit, no number (the forecaster's own chance of this, stated with the estimate: 75%); at least 1.6-fold (0.22 log units) between middle value and limit.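

In this assay, among these compounds, compound 1, compound 2 and compound 3 all stand as limits, and no step among them can be read. Still open, from the compounds shown here alone, is the concentration at which any of the three becomes cytotoxic, and whether either change shifts it.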